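The compounds below may be only part of what the source reports. "The series", "measured", "known", "first", "only" and "open" are said of these compounds alone.

Compound 1 `O/N=C(\CCN1CCN(c2ccccn2)CC1)c1ccccc1` gives 70% in a functional assay on HEK293 cells with D(4) dopamine receptor (Homo sapiens) as the target, read by FLIPR (a lower number here means a smaller maximal response, a higher number a larger maximal response), standing at the low end of the three numbers shown, with the other two within the scatter of it: compound 2 `O/N=C(/CCN1CCN(c2ccccn2)CC1)c1ccccc1` gives 74% and compound 3 `Cc1ccc(O)c(/C(CCN2CCN(c3ccccn3)CC2)=N/O)c1` gives 73%. The step of a number 4 percentage points higher from compound 1 to compound 2 (within the scatter) goes with the fact that compounds 1 and 2 differ only in the configuration as drawn, and the step of a number 3 percentage points higher from compound 1 to compound 3 (within the scatter) is also within the scatter. Compound 4 `C=CCO/N=C(\CCN1CCN(c2ccccn2)CC1)c1ccccc1` differs from compound 1 by allyl in place of hydrogen on an oxygen, a change at the oxygen that neither measured step touches. Both measured steps were small and neither bears directly on this change, so the expected step of no change at the digits printed from compound 1 to compound 4 (within the scatter) is none beyond the scatter. Compound 4 is therefore expected to give 70% in this assay, within 50% to 90%.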

Compound 4, largest response reached (reported as efficacy), in percent of the reference or control that the assay uses: 69%
Beside the measured number, compound 4's estimate is 1 percentage points above it, and the stated range covers the measured number.
By their numbers in this assay, from the lowest: compounds 4, 1, 3 and 2 (each within the scatter of the next).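

Among these compounds, at the oxygen carrying the double-bonded nitrogen, the earlier compounds showed no change, and hydroxy to allyloxy now gives the first reading there: in this assay the step is a number 1 percentage points lower from compound 1 to compound 4 (within the scatter) and so stays within the scatter. The hydrogen on this oxygen can thus give way to allyl with the maximal response still unchanged within the scatter. Nothing given here bears on why this step is so small.

As far as these compounds go, whether a benzyl group, a longer chain or a carboxylic acid at this oxygen would hold the response remains open. Also open, from the compounds shown here alone, is whether allyl would act alike on compound 2 or compound 3.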